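Moving the amino group on the phenyl substituent

The source may hold more compounds than are shown below. What is called first, only, known or untested is meant among the compounds shown, and "the series" means these compounds.

Values so far in a functional assay on the whole organism with Mus musculus as the target; a higher number here means that more compound is needed for the effect, a lower number that less compound is needed:
compound 1 `COc1cc2c(cc1OC)C(c1ccc(Br)cc1)=NNC(=O)C2` gives 110 umol/kg
compound 2 `COc1cc2c(cc1OC)C(c1ccc(N)cc1)=NNC(=O)C2` gives 15 umol/kg

Compound 2 holds the lower of the two numbers, so less of it is needed for the effect than of compound 1. Among the measured compounds shown here, the one measured step is a 7.3-fold lower number from compound 1 to compound 2 (0.87 log units; beyond the scatter) and lies beyond the scatter, with amino in place of bromo on an aromatic carbon.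

Next is compound 3 `COc1cc2c(cc1OC)C(c1cccc(N)c1)=NNC(=O)C2` and the change is 3-aminophenyl in place of 4-aminophenyl on a carbon with a double bond to nitrogen in short, 3-aminophenyl in place of 4-aminophenyl on a carbon with a double bond to nitrogen. For the measured compounds named here, no measured step moves the amino group, so the data bear on this change only indirectly. The step of a 7.3-fold lower number from compound 1 to compound 2 (0.87 log units; beyond the scatter) gives a rough upper scale, and a smaller change is expected in this assay here. Going by the values given here, compound 2 at 15 umol/kg is the lowest of only two numbers, so a higher number is the likelier direction. The expected step is a 2.3-fold higher number from compound 2 to compound 3 (0.37 log units; beyond the scatter) and it may not clear the scatter. For compound 3 the estimate is 35 umol/kg with an expected range from 14 umol/kg to 100 umol/kg.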

Compound 3, dose for half-maximal effect: 19.3 umol/kg
Estimate against measurement, compound 3: 1.8-fold (0.26 log units) above; low and high end bracket the measured number.
By their numbers in this assay, from the lowest: compounds 2 and 3 (each within the scatter of the next); then compound 1.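

In this assay, 3-aminophenyl in place of 4-aminophenyl on the carbon with a double bond to nitrogen gives a 1.3-fold higher number from compound 2 to compound 3 (0.11 log units; within the scatter), so this assay does not separate the two aminophenyl groups at this position. Among the compounds shown here, the comparison with the bromo compound gives a 5.7-fold lower number from compound 1 to compound 3 (0.76 log units; beyond the scatter), which lies beyond the scatter, as does a 7.3-fold lower number from compound 1 to compound 2 (0.87 log units; beyond the scatter); the lower number relative to 4-bromophenyl, previously seen only with 4-aminophenyl, therefore also holds for 3-aminophenyl, and none of the three compounds goes against this. No accompanying measurement bears on what lies behind these numbers.

Whether the amino group itself is required remains open, as the compounds shown leave unknown what a hydroxy, acetylamino or dimethylamino group would give on the same phenyl ring. Also open, as far as these compounds go, is whether the closeness of compound 2 and compound 3 carries over to a core with ethoxy groups in place of the two methoxy groups.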